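Substituted aryl variation at the shared core: compound 4

The compounds below may be only part of what the source reports. "The series", "measured", "known", "first", "only" and "open" are said of these compounds alone.

Compound 1 `CCOc1ccc(-c2ccc3ncn(-c4cc(OC)c(OC)c(OC)c4)c3c2)cc1` gives 8550 nM in a functional assay on A549 cells (Homo sapiens) for antiproliferative activity, read by MTT assay, with a stated time of 72 h; on this read-out higher numbers stand for weaker inhibition and lower numbers for stronger inhibition.
Compound 2 `COc1ccccc1-c1ccc2ncn(-c3cc(OC)c(OC)c(OC)c3)c2c1` gives 4320 nM in this assay.
Compound 3 `COc1ccc(-c2ccc3ncn(-c4cc(OC)c(OC)c(OC)c4)c3c2)cc1F` gives 1430 nM in this assay.

Compound 2 sits in the middle of the three numbers. Its value and that of compound 1 lie within the scatter of each other (a 2.0-fold lower number from compound 1 to compound 2 (0.30 log units; within the scatter)), while compound 3 stands clearly below it (a 3.0-fold lower number from compound 2 to compound 3 (0.48 log units; beyond the scatter)); compound 3 is also below compound 1 (a 6.0-fold lower number from compound 1 to compound 3 (0.78 log units; beyond the scatter)).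

Compound 4 `COc1cc(-n2cnc3ccc(-c4ccc(C)cc4)cc32)cc(OC)c1OC` differs from compound 2 by one change: 4-methylphenyl in place of 2-methoxyphenyl on an aromatic carbon.

All three measured steps exchange the same aryl group at this position, so they bear on the change, but none removes the methoxy group altogether or brings in a methyl group. Among the measured compounds shown here, the only step beyond the scatter came with 3-fluoro-4-methoxyphenyl; the exchange of 4-ethoxyphenyl for 2-methoxyphenyl stayed within the scatter. For compound 4 the expectation in this assay is therefore no step beyond the scatter from compound 2, written as a 1.0-fold higher number from compound 2 to compound 4 (0.02 log units; within the scatter), with a wide range in both directions. Compound 4 is estimated at 4500 nM, between 1500 nM and 13000 nM.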

Compound 4, half-maximal inhibitory concentration: 1940 nM
The estimate for compound 4 lay 2.3-fold (0.37 log units) above the measured number; measured number inside the range.
By their numbers in this assay, from the lowest: compounds 3 and 4 (each within the scatter of the next); then compounds 2 and 1 (each within the scatter of the next).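

At this position in this assay, a ring with no oxygen on it gives one of the lower numbers: 4-methylphenyl in place of 2-methoxyphenyl is a step beyond the scatter (a 2.2-fold lower number from compound 2 to compound 4 (0.35 log units; beyond the scatter)), and so is methyl in place of ethoxy (a 4.4-fold lower number from compound 1 to compound 4 (0.64 log units; beyond the scatter)). Until now only 3-fluoro-4-methoxyphenyl had stood clear of the other aryl groups, but 4-methylphenyl lies within the scatter of it (a 1.4-fold higher number from compound 3 to compound 4 (0.13 log units; within the scatter)), so among these four compounds the lower numbers do not depend on a fluorine or on an alkoxy group. No measurement at hand accounts for any of these steps.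

The compounds shown leave open what an unsubstituted phenyl ring would give here, so the contribution of the methyl group cannot be separated from the loss of the methoxy group. Also open, from the compounds shown here alone, is how this position responds to a 2-methylphenyl group, which would keep the substituent site of compound 2, or to a 4-aminophenyl group or a 4-carboxyphenyl group.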